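Exchanging the 2,3-difluorobenzyl group on a ring amine

The source may hold more compounds than are shown below. What is called first, only, known or untested is meant among the compounds shown, and "the series" means these compounds.

Of the compounds shown here, two sharing one core have been tested in a toxicity assay on MT2 cells (Homo sapiens) for cytotoxicity (on this read-out higher numbers stand for lower toxicity in this test and lower numbers for higher toxicity in this test), and neither gives a number. Compound 1 `Cc1nc(C)c([C@H](OC(C)(C)C)C(=O)O)c(N2CCC(C)(C)CC2)c1-c1cnc(OCCc2ccc(F)cc2)nc1` gives >= 22000 nM as a limit of the assay. Compound 2 `Cc1nc(C)c([C@H](OC(C)(C)C)C(=O)O)c(N2CCC(C)(C)CC2)c1-c1ccc2c(c1)CCN(Cc1cccc(F)c1F)C2` gives >= 24000 nM as a limit of the assay too. Compound 2 therefore cannot be ranked against compound 1 on these results. Compound 3 `Cc1nc(C)c([C@H](OC(C)(C)C)C(=O)O)c(N2CCC(C)(C)CC2)c1-c1ccc2c(c1)CCN(c1nc3cnccc3s1)C2` differs from compound 2 by the exchange a group of 9 heavy atoms (6 carbon, 2 nitrogen, 1 sulfur; one five-membered aromatic ring with 2 hetero atoms, one six-membered aromatic ring with 1 hetero atom) in place of a group of 9 heavy atoms (7 carbon, 2 fluorine; one six-membered aromatic ring of carbon only), on an amine nitrogen in a ring and keeps the rest of the structure. Within the data shown here, with no measured step to go on, the expected change in this assay is an at least 1.2-fold lower number from compound 2 to compound 3 (0.07 log units; that floor lies within the scatter) and stays within the usual scatter, with no firm direction. That expectation rests on compound 2 and its limit of >= 24000 nM alone. Compound 3 is estimated at 20000 nM with an expected range from 7000 nM to 50000 nM. Once measured, compound 3 may again give only a limit of the assay.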

Compound 3, half-maximal cytotoxic concentration: >= 17000 nM
Compound 3: no number, only a limit; the forecaster's own chance of this, stated with the estimate: 60%; the middle value is on the limit's open side.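

Compound 2 and compound 3 both give only limits in this assay, so the step between them cannot be read. The compounds shown leave open whether exchanging the 2,3-difluorobenzyl group on the ring amine changes the result in this assay at all, and where the actual values lie.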